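Methyl on the Amide Nitrogen: Solubility Outlook

The source may report more compounds than this note shows. Statements on the series, on what has been measured and on what is new or still open speak of the compounds shown alone.

Compound 2 `COc1ccc(-c2cc(-c3ccc(C(N)=O)cc3)cnc2N)cn1` carries a carbamoyl on an aromatic carbon of the shared core. In a physicochemical assay for solubility, read by nephelometry, measured as kinetic solubility, at pH 2 (on this read-out higher numbers stand for higher solubility and lower numbers for lower solubility), compound 2 gives > 100 ug/mL, which is a limit of the assay rather than a number. Its nearest measured neighbour is compound 1 `COc1ccc(-c2cc(-c3ccc(-n4cncn4)cc3)cnc2N)cn1`, which bears 1H-1,2,4-triazol-1-yl where compound 2 bears carbamoyl. In this assay compound 1 gives > 100 ug/mL, again a limit. The step that the two limits leave unreadable from compound 1 to compound 2 therefore cannot be read, as the limit of > 100 ug/mL in this assay, at which 2 of the 2 values shown sit, records. Compound 3 `CNC(=O)c1ccc(-c2cnc(N)c(-c3ccc(OC)nc3)c2)cc1` differs from compound 2 by methyl in place of hydrogen on an amide-type nitrogen, carbamoyl becoming methylcarbamoyl. Within the data shown here, no measured step bears on this change, and the single step available is unreadable, so no direction or size can be taken from it. The estimate for compound 3 is 100 ug/mL, within 30 ug/mL to 200 ug/mL, an expected step of a number no higher from compound 2 to compound 3 (the limit leaves the size open) that most probably ends once more at the limit.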

Compound 3, solubility: 50 ug/mL
Estimate against measurement, compound 3: 2.0-fold (0.30 log units) above; the measured number falls inside the stated range.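

In this assay, compound 3 is the first compound shown to give a number rather than a limit, so this position now has a value that later changes can be read against. Methyl in place of hydrogen on the amide-type nitrogen gives an at least 2.0-fold lower number from compound 2 to compound 3 (0.30 log units; that floor lies within the scatter), and methylcarbamoyl in place of 1H-1,2,4-triazol-1-yl gives an at least 2.0-fold lower number from compound 1 to compound 3 (0.30 log units; that floor lies within the scatter); each is a floor within the usual scatter, so neither step can yet be called a real drop. The true size of both steps stays open because the other end of each rests on a limit: the limit of > 100 ug/mL in this assay, at which 2 of the 3 values shown sit.

The compounds shown leave open how a longer chain such as ethyl on the same amide-type nitrogen would read in this assay, and whether a second methyl there would give a lower number still. They also leave open how a carboxylic acid on that aromatic carbon would compare with carbamoyl and methylcarbamoyl.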